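The source may hold more compounds than are shown below. What is called first, only, known or untested is meant among the compounds shown, and "the series" means these compounds.

Measured in a functional assay on SK-MEL-28 cells (Homo sapiens) for inhibition, read by colorimetric assay and MTT assay, with a stated time of 72 h; a lower number here means a stronger inhibitor, a higher number a weaker inhibitor:
compound 1 `CCCCCCOc1ncc(-c2ccccc2OC)n1C`: 43000 nM
compound 2 `C=CCCOc1ncc(-c2ccccc2OC)n1C`: 21000 nM
compound 3 `C=CCCCCOc1ncc(-c2ccccc2OC)n1C`: 13000 nM

These three compounds share a core and differ only in the chain on the oxygen. Compound 3 is set apart from only one of the other two: the data show a 3.3-fold lower number from compound 1 to compound 3 (0.52 log units; beyond the scatter), whereas they also show a 1.6-fold lower number from compound 2 to compound 3 (0.21 log units; within the scatter).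

Compound 4 `C=CCCCCOc1ncc(-c2cc(Cl)ccc2OC)n1C` keeps the chain of compound 3 and makes a single change: chloro in place of hydrogen on an aromatic carbon. The measured steps offer only indirect guidance. Besides the two above, the data show a 2.0-fold lower number from compound 1 to compound 2 (0.31 log units; beyond the scatter), and all three steps alter the chain, with none touching the aromatic ring that gains the chloro. Within the data shown here, they are small, and no measured compound shows what a chloro does here. No step beyond the scatter is therefore expected in this assay, and no direction is favoured with any confidence. The expectation starts from compound 3 at 13000 nM. The estimated outcome is a 1.2-fold lower number from compound 3 to compound 4 (0.07 log units; within the scatter). For compound 4 the estimated value is 11000 nM, with an expected range of 4000 nM to 30000 nM.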

Compound 4, half-maximal inhibitory concentration: 28000 nM
For compound 4 the middle estimate is 2.5-fold (0.41 log units) below the measured one; measured number inside the range.
By their numbers in this assay, from the lowest: compounds 3, 2, 4 and 1 (each within the scatter of the next, the first and the last beyond it).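

Every earlier step changed the chain on the oxygen, so the aromatic ring had no measured reading until now. In this assay, chloro in place of hydrogen on this aromatic carbon, para to a methoxy group and meta to a large group, gives a 2.2-fold higher number from compound 3 to compound 4 (0.33 log units; beyond the scatter) while the chain stays the same, so a change at this position can make the compound a weaker inhibitor, though the step is modest. Nothing available here explains why the number moves this way.

The compounds shown leave open whether fluoro, methyl or an amine on the same carbon would shift the number in the same direction. Going by these compounds, it also remains open whether chloro would give a similar step with a different chain on the oxygen, such as but-3-en-1-yl or a longer chain.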